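The compounds below may be only part of what the source reports. "The series", "measured", "known", "first", "only" and "open" are said of these compounds alone.

Working notes on the series, read in an ADME assay on BJ cells (Homo sapiens) for cytotoxicity, with a stated time of 72 h; on this read-out higher numbers stand for an effect only at larger amounts of compound and lower numbers for an effect already at smaller amounts. Compound 1 (`COC(=O)C1CCN(c2cc(Cl)c(C(=O)Nc3cc(-c4nc5ccccc5s4)ccc3C)cc2[N+](=O)[O-])CC1`) gives > 25000 nM, which is a limit of the assay and not a number. Compound 2 (`O=C(Nc1ccc(O)c(-c2nc3ccccc3s2)c1)c1cc([N+](=O)[O-])ccc1Cl`) gives > 25000 nM, also only a limit. The measured record therefore stands at the limit of > 25000 nM in this assay, at which 2 of the 2 values shown sit, and no number is available for either compound.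

Compound 3 (`Cc1ccc(-c2nc3ccccc3s2)cc1NC(=O)c1cc([N+](=O)[O-])ccc1Cl`) is the next to be read. The change is hydrogen in place of 4-(methoxycarbonyl)piperidin-1-yl on an aromatic carbon: hydrogen replaces 4-(methoxycarbonyl)piperidin-1-yl on an aromatic carbon, ortho to a nitro group and meta to a chloro group. Within the data shown here, no measured step exists to size this change, so the expectation rests on the two limits alone. No shift beyond the scatter, in either direction, is expected in this assay, and the estimated a number no higher from compound 1 to compound 3 (the limit leaves the size open) reflects this. For compound 3 the estimated value is 25000 nM, with an expected range of 12000 nM to 50000 nM.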

Compound 3, half-maximal effective concentration: > 14000 nM
Compound 3 was reported as a limit; the forecaster's own chance of this, stated with the estimate: 85%; the middle value does not contradict the limit.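

Compound 1 and compound 3 both stand only as limits in this assay, so the change from compound 1 to compound 3, hydrogen in place of 4-(methoxycarbonyl)piperidin-1-yl, gives no readable step. The compounds shown leave open whether, and at what concentration, any of them reaches a half-maximal effect.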